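A few compounds are considered here, and "the series" means these few. Any claim that something is new, unique, unknown or untested is made for them only; others in the source may bear on it.

Measured in a functional assay on K562 cells (Homo sapiens) for antiproliferative activity, with a stated time of 72 h; a higher number here means a weaker inhibitor, a lower number a stronger inhibitor:
- compound 1 `OC[C@H]1O[C@@H](n2cnc3c(NCc4ccccc4Br)ncnc32)[C@H](O)[C@@H]1O`: 10000 nM
- compound 2 `OC[C@H]1O[C@@H](n2cnc3c(NCc4ccc(Cl)c(Cl)c4)ncnc32)[C@H](O)[C@@H]1O`: 10800 nM
- compound 3 `COc1cccc(CNc2ncnc3c2ncn3[C@@H]2O[C@H](CO)[C@@H](O)[C@H]2O)c1OC`: > 166000 nM

Compound 3 is the weakest of the three. Its value is a limit and not a number, as the limit of > 166000 nM in this assay, at which 1 of the 3 values shown sits, records. Compound 1 and compound 2 sit together, with a 1.1-fold higher number from compound 1 to compound 2 (0.03 log units; within the scatter).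

Compound 4 `OC[C@H]1O[C@@H](n2cnc3c(NCc4c(F)ccc(F)c4F)ncnc32)[C@H](O)[C@@H]1O` has not yet been measured. It carries 2,3,6-trifluorophenyl in place of 2,3-dimethoxyphenyl on a saturated chain carbon bound to a nitrogen on an aromatic ring.

Going by the values given here, two measured steps bear on this change, since both end at the same 2,3-dimethoxyphenyl compound. Starting from the halogen-bearing compound 1 there is an at least 16-fold higher number from compound 1 to compound 3 (1.22 log units; beyond the scatter), and starting from compound 2 there is an at least 15-fold higher number from compound 2 to compound 3 (1.18 log units; beyond the scatter). Both are large. Compound 4 leaves that same group for a halogen-bearing phenyl, so a large step towards a lower number is expected in this assay, back towards compound 1 and compound 2. Neither of those two carries fluorine, however, and the expectation stays loose.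

The expected step is an at least 8.3-fold lower number from compound 3 to compound 4 (0.91 log units; beyond the scatter). For compound 4 the estimated value is 20000 nM, with an expected range from 6000 nM to 100000 nM.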

Compound 4, half-maximal inhibitory concentration: > 166000 nM
Compound 4: a limit, no number; the forecaster's own chance of this, stated with the estimate: 25%; middle value at least 8.3-fold (0.91 log units) away from the limit.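

In this assay, a halogen-bearing phenyl at this place is not enough to keep the level of compound 1 and compound 2: putting 2,3,6-trifluorophenyl in place of 2-bromophenyl gives an at least 16-fold higher number from compound 1 to compound 4 (1.22 log units; beyond the scatter), and putting it in place of 3,4-dichlorophenyl gives an at least 15-fold higher number from compound 2 to compound 4 (1.18 log units; beyond the scatter). Compound 4 stands at a limit of the assay and not at a number, as compound 3 does: the limit of > 166000 nM in this assay, at which 2 of the 4 values shown sit. The step between compound 3 and compound 4 cannot be read, so 2,3,6-trifluorophenyl and 2,3-dimethoxyphenyl cannot be ranked against each other, and the earlier contrast between halogen-bearing and methoxy-bearing phenyl groups no longer holds, with compound 4 going against it.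

The compounds shown leave open whether the result follows from fluorine as the halogen or from the number of halogens and where they sit on the ring. As far as these compounds go, how a phenyl carrying a single fluorine, an unsubstituted phenyl or a phenyl carrying a single methoxy would fall at this place also remains open.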